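From propoxycarbonyl to benzyloxycarbonyl on a shared core

This account rests on a few compounds, and the source may have more. Where it says the series, first, only, none or still open, it means among the compounds named here.

Measured in a functional assay on HeLa cells (Homo sapiens) for antiproliferative activity, read by MTT assay, with a stated time of 48 h; on this read-out lower numbers stand for stronger inhibition of growth and higher numbers for weaker inhibition of growth:
compound 1 `COc1ccc(C2=NN(C(=O)OCc3ccccc3)C(c3cc(OC)c(OC)c(OC)c3)C2)cc1`: > 10000 nM
compound 2 `CCOC(=O)N1N=C(c2cccc(O)c2)CC1c1cc(OC)c(OC)c(OC)c1`: 3280 nM
compound 3 `CCCOC(=O)N1N=C(c2cccc(O)c2)CC1c1cc(OC)c(OC)c(OC)c1`: > 10000 nM

Compound 3 gives > 10000 nM, which is a limit of the assay and not a number. It shares that position with one other compound, as the limit of > 10000 nM in this assay, at which 2 of the 3 values shown sit, shows. Only compound 2 has a measured number, 3280 nM.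

Compound 4 `COc1cc(C2CC(c3cccc(O)c3)=NN2C(=O)OCc2ccccc2)cc(OC)c1OC` differs from compound 3 by phenyl in place of ethyl on a saturated chain carbon bound to an oxygen next to a carbonyl group, so propoxycarbonyl becomes benzyloxycarbonyl.

Within the data shown here, the one measured step on this chain is an at least 3.0-fold higher number from compound 2 to compound 3 (0.48 log units; beyond the scatter), and it went towards weaker inhibition of growth. Compound 1 also bears benzyloxycarbonyl, and its > 10000 nM is likewise a limit. Neither observation points to a recovery in this assay, so no clear gain is expected. The expected step is a number no higher from compound 3 to compound 4 (the limit leaves the size open), and its true size stays uncertain while compound 3 has only a limit.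

For compound 4 the estimated value is 10000 nM, with an expected range of 3000 nM to 30000 nM.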

Compound 4, concentration for 50% growth inhibition: > 10000 nM
Compound 4: only a limit was reported; the forecaster's own chance of this, stated with the estimate: 60%; the middle value lies on the limit itself.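

In this assay compound 4 gives > 10000 nM, which is a limit and not a number. The step of an at least 3.0-fold higher number from compound 2 to compound 4 (0.48 log units; beyond the scatter) shows that phenyl in place of methyl at this position, on a saturated chain carbon bound to an oxygen next to a carbonyl group, moves towards weaker inhibition of growth, so the longer propoxycarbonyl is not the only replacement of ethoxycarbonyl to do so. The steps to compound 4 from compound 3 and from compound 1 have limits at both ends and cannot be read.

Only compound 2 stands off the limit, so the order among the other compounds stays hidden: the limit of > 10000 nM in this assay, at which 3 of the 4 values shown sit.

From the compounds shown here alone, whether a shorter methoxycarbonyl, or a chain carrying an amine, at this position would match or better compound 2 at 3280 nM remains open.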